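Sulfonyl substituent swap on compound 1: solubility notes

The source may report more compounds than this note shows. Statements on the series, on what has been measured and on what is new or still open speak of the compounds shown alone.

Measured in a physicochemical assay for solubility; on this read-out lower numbers stand for lower solubility and higher numbers for higher solubility:
- compound 1 `CCn1c(=O)c2nc(-c3ccc(S(=O)(=O)NCCN(C)C)cc3)[nH]c2n(CC)c1=O`: 11500 ug/mL
- compound 2 `CCCn1c(=O)c2nc(-c3ccc(Cl)cc3N)[nH]c2n(CCC)c1=O`: 0.4 ug/mL

Of the two measured compounds, compound 1 stands highest at 11500 ug/mL, and the gap down to compound 2 at 0.4 ug/mL lies far beyond the scatter. Compound 2 differs from compound 1 in more than one place, so this gap gives no size for a single change.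

The next compound to be measured is compound 3 `CCn1c(=O)c2nc(-c3ccc(S(=O)(=O)O)cc3)[nH]c2n(CC)c1=O`. It carries hydroxy in place of (2-(dimethylamino)ethyl)amino on a sulfonyl sulfur, with the rest of compound 1 kept: hydroxy in place of (2-(dimethylamino)ethyl)amino on a sulfonyl sulfur.

For the measured compounds named here, no step between measured compounds is available to guide this change, so the expectation is only a judgement anchored on compound 1 at 11500 ug/mL. A small downward move in this assay is expected, close to the scatter, though the data cannot exclude a larger one. The estimated change is a 1.9-fold lower number from compound 1 to compound 3 (0.28 log units; within the scatter). For compound 3 the expected value is 6000 ug/mL, with an estimated range of 1500 ug/mL to 25000 ug/mL.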

Compound 3, solubility: > 8000 ug/mL
Compound 3 gave a limit, no number; the forecaster's own chance of this, stated with the estimate: 10%; middle value at least 1.3-fold (0.12 log units) from the limit.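

For the compounds shown here, compound 3 gave only a limit in this assay, > 8000 ug/mL, not a number, so no step from compound 1 to compound 3 can be read. The compounds shown leave open the size and direction of the change in this assay when hydroxy replaces (2-(dimethylamino)ethyl)amino on a sulfonyl sulfur.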